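The source may report more compounds than this note shows. Statements on the series, on what has been measured and on what is new or still open speak of the compounds shown alone.

In a functional assay on DU-145 cells (Homo sapiens) for inhibition, read by trypan blue exclusion, with a stated time of 96 h (a lower number here means a stronger inhibitor of growth, a higher number a weaker inhibitor of growth), compound 1 `Cc1ccc(/C=C(/SCc2ccc(Cl)cc2)C(=O)c2ccc(Cl)cc2)s1` gives 50000 nM. Compound 2 `Cc1ccc(/C=C(/SCc2ccc(F)cc2)C(=O)c2ccc(Cl)cc2)s1` gives > 100000 nM, which is a limit of the assay and not a number. Compound 2 therefore has no exact position in the series, and any step away from it is only loosely anchored.

The next structure is compound 3 `COc1ccc(S/C(=C/c2ccc(C)s2)C(=O)c2ccc(Cl)cc2)cc1`, which has 4-methoxyphenyl in place of 4-fluorobenzyl on a sulfur.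

Among the compounds with values here, the one measured step is an at least 2.0-fold higher number from compound 1 to compound 2 (0.30 log units; that floor lies within the scatter), with fluoro in place of chloro on an aromatic carbon. Its floor lies within the scatter, its true size is open, and it does not change the group on the sulfur, so it bears on the new change only indirectly. Within the data shown here, no measured step replaces that group. Among the measured compounds shown here, compound 1 at 50000 nM shows only that a measurable number is possible in this small set, so no step beyond the scatter is expected in this assay, and no direction can be assigned with confidence. The expected change is an at least 1.2-fold lower number from compound 2 to compound 3 (0.09 log units; that floor lies within the scatter), and another limit reading would be no surprise. For compound 3 the estimated value is 80000 nM, within an expected range of 30000 nM to 200000 nM.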

Compound 3, concentration for 50% growth inhibition: 50000 nM
For compound 3 the middle estimate is 1.6-fold (0.20 log units) above the measured one; the measured number falls inside the stated range.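

In this assay the group on the sulfur now has a measured step of its own: 4-methoxyphenyl in place of 4-fluorobenzyl gives an at least 2.0-fold lower number from compound 2 to compound 3 (0.30 log units; that floor lies within the scatter). That step is only a floor, and its true size stays open because compound 2 stands at a limit and not at a number: the limit of > 100000 nM in this assay, at which 1 of the 3 values shown sits.

The comparison with a readable partner is firmer, since 4-methoxyphenyl in place of 4-chlorobenzyl gives no change at the digits printed from compound 1 to compound 3 (within the scatter), so these two groups on the sulfur cannot be told apart in this assay, and a benzyl group is not required for a measurable number here.

Still open, from the compounds shown here alone, is whether any group on the sulfur moves the number well away from these values, for instance a chain carrying an amine or a phenyl ring carrying a carboxylic acid. A 4-methoxybenzyl group on the sulfur would be needed to separate the contribution of the methoxy group from that of the benzyl carbon in the change from 4-fluorobenzyl to 4-methoxyphenyl.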